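This account rests on a few compounds, and the source may have more. Where it says the series, first, only, none or still open, it means among the compounds named here.

Compound 1 `Cc1ccc2nc(C(=O)Nc3c(F)cc(-c4cccc(F)c4)cc3F)c(C)c(O)c2c1` is tested in a functional assay on Hep 3B2 cells (Homo sapiens) for antiproliferative activity, read by MTT assay, with a stated time of 24 h, tested at 33.33 ug/mL (a higher number here means a stronger effect of the compound at the concentration tested, a lower number a weaker effect), where compound 1 gives 37.3%. Compound 3 `Cc1ccc2nc(C(=O)Nc3c(F)cc(-c4cccc(F)c4)cc3F)c(C)c(C(=O)O)c2c1` differs from it by carboxy in place of hydroxy on an aromatic carbon, and in this assay compound 3 gives 41.3%, so that a number 4 percentage points higher from compound 1 to compound 3 (within the scatter). Compound 2 `COc1ccc2nc(C(=O)Nc3ccc(-c4ccccc4)cc3)c(C)c(O)c2c1` is built on a core whose difference from the core of compound 1 is not broken down here; in this assay compound 2 gives 48.4%, a number within the scatter of that of compound 3 and beyond the scatter of that of compound 1. Compound 4 `COc1ccc2nc(C(=O)Nc3ccc(-c4ccccc4)cc3)c(C)c(C(=O)O)c2c1` is not yet measured; it carries carboxy in place of hydroxy on an aromatic carbon, the same change in the same place as that from compound 1 to compound 3. Because the earlier step of a number 4 percentage points higher from compound 1 to compound 3 (within the scatter) was small, a similarly small step a number 1.6 percentage points higher from compound 2 to compound 4 (within the scatter) is expected beside it. Compound 4 is estimated at 50%.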

Compound 4, a percentage reported as inhibition, at one concentration (the size of the read-out at that concentration, not a potency): 33.6%
Estimate against measurement, compound 4: 16.4 percentage points above; the whole stated range lies above it.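

In this assay, carboxy in place of hydroxy on an aromatic carbon gives a number 14.8 percentage points lower from compound 2 to compound 4 (beyond the scatter). The same change therefore does not carry over with the same outcome from one core to the other: the same change on two cores in this assay, a number 4 percentage points higher (within the scatter) from compound 1 to compound 3 and a number 14.8 percentage points lower (beyond the scatter) from compound 2 to compound 4, 18.8 percentage points apart, beyond the scatter of two such steps. This shows that, in these two pairs, the result of the change depends on the core, but it does not show which of the differences between the cores matters, and two pairs set no rule for the series.

From the compounds shown here alone, it remains open whether an amine or a carboxamide on that aromatic carbon would follow either step. Also open, going by these compounds, is how the change behaves on a core that shares only some of those differences.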